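This account rests on a few compounds, and the source may have more. Where it says the series, first, only, none or still open, it means among the compounds named here.

Among the measured compounds shown here, compound 2 `CCCSc1nsnc1[C@@H]1CN2CCC[C@H]1C2` gives the only number in a functional assay on the whole organism for inhibition, with Mus musculus as the target (on this read-out higher numbers stand for an effect only at larger amounts of compound and lower numbers for an effect already at smaller amounts), namely 0.17 mg/kg. Compound 1 `CCCCSc1nsnc1[C@H]1CN2CCC[C@H]1C2` reaches only a limit in this assay, > 1 mg/kg. Of the two values shown, one thus sits at the limit of > 1 mg/kg in this assay, at which 1 of the 2 values shown sits. Compound 3 `CCCSc1nsnc1[C@H]1CN2CCC[C@H]1C2` differs from compound 2 in that (the two compounds have the same atoms and bonds; at least one stereo element is drawn with a configuration in one of them and without one in the other: 1 of 3 stereo elements differ; a stereocentre at a saturated ring carbon is drawn S in compound 2 and R in compound 3). For the measured compounds named here, no step between measured compounds covers such a change, and its size is open. The step of an 8.8-fold higher number from compound 2 to compound 3 (0.95 log units; beyond the scatter) is expected to be a weakening beyond the scatter. Compound 3 is therefore estimated at 1.5 mg/kg, within a range from 0.3 mg/kg to 8 mg/kg, with a fair chance that only a limit is found.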

Compound 3, dose for half-maximal effect: 2.21 mg/kg
Compound 3: the middle estimate sits 1.5-fold (0.17 log units) below what was measured; low and high end bracket the measured number.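

In this assay, changing a single stereocentre at a saturated ring carbon from S to R, with atoms and bonds the same, gives a 13-fold higher number from compound 2 to compound 3 (1.11 log units; beyond the scatter), so the configuration at this carbon alone shifts the dose needed for an effect. Compound 1 reaches only a limit, > 1 mg/kg. Its step to compound 3, hydrogen in place of methyl on a saturated chain carbon, therefore cannot be read.

As far as these compounds go, it stays open whether the configuration at this carbon counts as much with an amine or a phenyl group on the sulfur chain.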